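The compounds below may be only part of what the source reports. "The series", "measured", "known", "first", "only" and "open" are said of these compounds alone.

Compound 1 is `O=C(O)C(CS)C1CCNCC1` and gives 37 nM. Compound 2 is `N=C(N)N1CCCC(C(CS)C(=O)O)C1` and gives 165 nM; 45 nM (2 entries). Compound 3 is `O=C(O)C(CS)C1CCCNC1` and gives 445 nM; 68 nM (2 entries).

Among the compounds with values here, in an assay on isolated protein for inhibition of carboxypeptidase B2 (Homo sapiens) (on this read-out lower numbers stand for stronger inhibition and higher numbers for weaker inhibition), compound 1 is the one compound with a single value, whereas compound 2 and compound 3 each have several entries that are spread apart. Compound 4, `CC(=N)N1CCC(C(CS)C(=O)O)CC1`, has not yet been measured in this assay. It differs from compound 1 by a group of 3 heavy atoms (2 carbon, 1 nitrogen; no ring) in place of a hydrogen atom, on an amine nitrogen in a ring. Within the data shown here, no directly comparable measured pair exists, but the several entries of compound 2 in this assay, 165 nM; 45 nM (2 entries) and the several entries of compound 3 in this assay, 445 nM; 68 nM (2 entries) overlap, so in this assay the step is expected to stay within the usual scatter. Compound 4 is estimated at 25 nM, within 6 nM to 100 nM, a change a 1.5-fold lower number from compound 1 to compound 4 (0.17 log units; within the scatter).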

Compound 4, half-maximal inhibitory concentration: 5300 nM
For compound 4 the middle estimate is 210-fold (2.33 log units) below the measured one; the measured number lies above the stated range.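

In this assay, a group of 3 heavy atoms (2 carbon, 1 nitrogen; no ring) in place of a hydrogen atom, on an amine nitrogen in a ring, gives a 140-fold higher number from compound 1 to compound 4 (2.16 log units; beyond the scatter). Within the data shown here, this is the first step that can be read at this position, and it shows that the inhibition of the shared core depends strongly on what this nitrogen carries. Nothing measured here accounts for the size of this step.

The compounds shown leave open whether a methyl or an acetyl group on this nitrogen would cost as much. They also leave open whether the loss belongs to this particular group or to any replacement of the hydrogen atom.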